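One Change on the Aromatic Ring of Compound 2

The compounds below may be only part of what the source reports. "The series", "measured", "known", "first", "only" and "open" are said of these compounds alone.

Compound 2 `CC#C[C@H]1CN(S(=O)(=O)c2ccc(N)nc2)CCN1c1ccc(S(=O)(=O)NCC2CC2)cc1` gives the lowest of the two numbers in hand. In an assay on cells (Hepatocyte) for inhibition of glucokinase regulatory protein (Mus musculus), with stated times of 20 min and 40 min (a higher number here means that more compound is needed for the effect, a lower number that less compound is needed), compound 2 gives 271 nM, whereas compound 1 `CC#C[C@H]1CN(S(=O)(=O)c2ccc(N)nc2)CCN1c1ccc(C(C)(O)C(F)(F)F)nc1` gives 1450 nM, a gap that lies beyond the scatter of repeated measurements. Compound 3 `CC#C[C@H]1CN(S(=O)(=O)c2ccc(N)nc2)CCN1c1ccc(S(=N)(=O)C2CC2)cc1` has not yet been measured; it differs from compound 2 at a single place, where (a group of 6 heavy atoms (3 carbon, 1 nitrogen, 1 oxygen, 1 sulfur; one three-membered non-aromatic ring of carbon only) in place of a group of 8 heavy atoms (4 carbon, 1 nitrogen, 2 oxygen, 1 sulfur; one three-membered non-aromatic ring of carbon only), on an aromatic carbon). Within the data shown here, no step between two measured compounds mirrors this change, so the expectation for compound 3 rests on compound 2 alone and on the modest size of the change. The step from compound 2 to compound 3 in this assay is expected to be small, a 1.1-fold higher number from compound 2 to compound 3 (0.04 log units; within the scatter), with no direction that would reach beyond the scatter. Compound 3 is therefore estimated at 300 nM in this assay, with a likely range from 100 nM to 900 nM.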

Compound 3, half-maximal effective concentration: 208 nM
Beside the measured number, compound 3's estimate is 1.4-fold (0.16 log units) above it; low and high end bracket the measured number.
By their numbers in this assay, from the lowest: compounds 3 and 2 (each within the scatter of the next); then compound 1.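

In this assay, exchanging the (cyclopropylmethyl)sulfamoyl group on this aromatic carbon, para to a large group, gives a 1.3-fold lower number from compound 2 to compound 3 (0.11 log units; within the scatter), a step within the scatter. Among these compounds, this is the first step read at this place, and it shows that the assay number does not separate the two groups, even though the entering group has fewer heavy atoms and keeps the three-membered carbon ring and the same tally of hydrogen-bond donors and acceptors. No measurement is at hand that would explain this outcome.

The compounds shown leave open whether the three-membered ring itself matters, since both groups carry it and neither a propyl chain nor a methyl group stands in its place. They also leave open how a carboxylic acid or an amine on the same aromatic carbon would fare in this assay.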